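Chlorine Additions on Three Compounds That Show No Inhibition

This account rests on a few compounds, and the source may have more. Where it says the series, first, only, none or still open, it means among the compounds named here.

Compound 1 `Clc1cc2nc(Cl)n(Cc3ccccc3)c2cc1Cl` was tested in a functional assay on KB cells (Homo sapiens) for inhibition; on this read-out lower numbers stand for stronger inhibition and higher numbers for weaker inhibition. In this assay compound 1 gives > 100000 nM, which is a limit of the assay rather than a number. Compound 2 `Clc1ccc(Cn2c(Cl)nc3cc(Cl)c(Cl)cc32)cc1` differs from compound 1 by chloro in place of hydrogen on an aromatic carbon. In this assay compound 2 gives > 100000 nM, again a limit. The step that the two limits leave unreadable from compound 1 to compound 2 therefore cannot be sized. Compound 3 `Clc1ccc(Cn2c(Br)nc3cc(Cl)c(Cl)cc32)cc1` follows; in this assay compound 3 gives > 100000 nM, also a limit, and the step that the two limits leave unreadable from compound 2 to compound 3 is likewise unreadable. How the core of compound 3 differs from the core of compound 1 is not broken down here. All three values sit at the same limit (the limit of > 100000 nM in this assay, at which 3 of the 3 values shown sit).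

Compound 4 `Clc1ccc(Cn2c(Br)nc3cc(Cl)c(Cl)cc32)cc1Cl` is not yet measured and differs from compound 3 by chloro in place of hydrogen on an aromatic carbon. This is the same kind of change as from compound 1 to compound 2, though not the same: in compound 2 the chloro sits para to a large group, while in compound 4 it sits ortho to a chloro group and meta to a large group. Because every measured compound sits at the limit of > 100000 nM in this assay, at which 3 of the 3 values shown sit, the step that the limit leaves unreadable from compound 3 to compound 4 is expected to be small and no readable number is expected. Compound 4 is expected to give 150000 nM.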

Compound 4, half-maximal inhibitory concentration: > 100000 nM
Compound 4 ended at the assay's limit; the forecaster's own chance of this, stated with the estimate: 90%; the middle value is on the limit's open side.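

For the compounds shown here, no step can be sized from compound 3 to compound 4, because both values are limits of this assay and not numbers: the limit of > 100000 nM in this assay, at which 4 of the 4 values shown sit.

The compounds shown leave open whether any change to the shared core or its attached groups would give a readable value for inhibition at all.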